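This account rests on a few compounds, and the source may have more. Where it says the series, first, only, none or still open, it means among the compounds named here.

Compound 1 `O=C1/C(=C/c2ccc(F)cc2)CCc2ccccc21`: 33400 nM
Compound 2 `O=C1CCCCC/C1=C\c1cccc(Cl)c1`: 40500 nM

In a functional assay on CCRF-CEM cells (Homo sapiens) for inhibition (on this read-out higher numbers stand for weaker inhibition and lower numbers for stronger inhibition), compound 2 at 40500 nM lies within the usual scatter of compound 1 at 33400 nM. Compound 3 `O=C1CCCCC/C1=C\c1cccc([N+](=O)[O-])c1` carries nitro in place of chloro on an aromatic carbon, meta to a group of 9 heavy atoms (nitro in place of chloro on an aromatic carbon). Going by the values given here, no measured pair shows this exchange, so the expectation rests on little, and no step beyond the scatter is expected in this assay, in either direction. The expected change is a 1.3-fold lower number from compound 2 to compound 3 (0.10 log units; within the scatter). For compound 3 the estimated value is 32000 nM, with an expected range from 12000 nM to 75000 nM.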

Compound 3, half-maximal inhibitory concentration: 30100 nM
Estimate against measurement, compound 3: 1.1-fold (0.03 log units) above, and the stated range covers the measured number.
By their numbers in this assay, from the lowest: compounds 3, 1 and 2 (each within the scatter of the next).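

At the aromatic carbon meta to a group of 9 heavy atoms, nitro in place of chloro gives, in this assay, a 1.3-fold lower number from compound 2 to compound 3 (0.13 log units; within the scatter). Going by these compounds alone, the first measured exchange at this position therefore leaves the number within the scatter, although the entering group is larger and brings hydrogen-bond acceptors. Nothing measured here offers an explanation for this.

The compounds shown leave open whether an amine or a carboxylic acid on this same carbon would give a step beyond the scatter.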